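This account rests on a few compounds, and the source may have more. Where it says the series, first, only, none or still open, it means among the compounds named here.

Measured so far in a functional assay on NCI-H460 cells (Homo sapiens) for cytotoxicity, read by MTT assay, with a stated time of 72 h; a lower number here means a stronger inhibitor, a higher number a weaker inhibitor:

Compound 1 `CCN(CC)Cc1ccc2nc(NC(=O)N/N=C/c3cn(Cc4ccc(C(C)(C)C)cc4)c4ccccc34)sc2c1` gives 1670 nM
Compound 2 `CC1CCN(Cc2ccc3nc(NC(=O)N/N=C/c4cn(Cc5ccc(Cl)cc5Cl)c5ccccc45)sc3c2)CC1` gives 1660 nM
Compound 3 `CN(C)Cc1ccc2nc(NC(=O)N/N=C3\C(=O)Nc4ccc(Cl)cc43)sc2c1` gives 1170 nM

These values sit close together. Compound 2 lies within the usual scatter of both compound 1 and compound 3, so it holds no separate place among them. Going by the values given here, no two of the three differ in only one place, which means that no measured step shows the effect of a single change.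

Compound 4 `CC1CCN(Cc2ccc3nc(NC(=O)N/N=C/c4c[nH]c5ccccc45)sc3c2)CC1` is compound 2 with one change, counted as hydrogen in place of 2,4-dichlorobenzyl on an aromatic nitrogen, putting hydrogen in place of 2,4-dichlorobenzyl on an aromatic nitrogen. This removes a large group, and the data contain no direct comparison for doing so. Compound 2 gives 1660 nM with that group in place. Compound 3 gives 1170 nM without any benzyl group, but on a different structure, so it offers only loose guidance. A moderate move towards weaker inhibition is therefore expected, though a result within the scatter would not be surprising. The estimated change is a 1.8-fold higher number from compound 2 to compound 4 (0.26 log units; within the scatter), and this remains an expectation until measured. For compound 4 the estimated value is 3000 nM, with an expected range from 800 nM to 11000 nM in this test.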

Compound 4, half-maximal inhibitory concentration: 4130 nM
Estimate against measurement, compound 4: 1.4-fold (0.14 log units) below; low and high end bracket the measured number.
By their numbers in this assay, from the lowest: compounds 3, 2 and 1 (each within the scatter of the next); then compound 4.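

In this assay, going by these compounds alone, replacing 2,4-dichlorobenzyl with hydrogen on the aromatic nitrogen gives a 2.5-fold higher number from compound 2 to compound 4 (0.40 log units; beyond the scatter), and this is the first step here that isolates a single change. The pair shows that this position affects the result: the step is modest but lies beyond the usual scatter, and the compound bearing the 2,4-dichlorobenzyl group is the stronger of the two. It also shows that the group, with its nine heavy atoms and its aromatic ring, is not required for a measurable result, since compound 4 still gives a value in this test. No measurement here explains why the number rises.

The compounds shown leave open which part of the group matters, and a plain benzyl group without chlorine, or a methyl group on the same nitrogen, would help to separate the contribution of the ring from that of the two chlorines. Going by these compounds, it also remains open whether the step would keep its size if a morpholine replaced the 4-methylpiperidine on the shared core.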